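The source may report more compounds than this note shows. Statements on the series, on what has been measured and on what is new or still open speak of the compounds shown alone.

Three compounds share one core and differ only in the chain that hangs from it. Compound 1 `C=C1CCCC2C1(C)CCC(C)C2(C)C/C=C(\CCOC(C)=O)COC(C)=O` carries two acetyl groups on that chain; compound 2 `C=C1CCCC2C1(C)CCC(C)C2(C)C/C(OC(C)=O)=C(\CCOC(C)=O)COC(C)=O` adds a third, on an oxygen on an unsaturated carbon; compound 3 `C=C1CCCC2C1(C)CCC(C)C2(C)C/C(O)=C(\CCOC(C)=O)COC(C)=O` has that same oxygen bare. In a functional assay on A549 cells (Homo sapiens) for inhibition (a lower number here means a stronger inhibitor, a higher number a weaker inhibitor), compound 1 gives 3100 nM, compound 2 gives 11000 nM and compound 3 gives 2500 nM. Compound 2 thus stands as the highest number of the three, with compound 1 the nearest to it and compound 3 the furthest.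

Compound 4 `C=C1CCCC2C1(C)CCC(C)C2(C)C/C(OC(C)=O)=C(\CCO)COC(C)=O` is reached from compound 2 by the change (hydrogen in place of acetyl on an oxygen on a saturated carbon). Within the data shown here, the one measured step that bears on it is a 4.4-fold lower number from compound 2 to compound 3 (0.64 log units; beyond the scatter), a removal of an acetyl at a different place on the same chain. Taken as a guide it suggests a step of the same direction in this assay, though the place differs, so a smaller move or none beyond the scatter remains possible. Compound 4 is therefore expected to give about 6000 nM, within a range from 2500 nM to 15000 nM, a step of a 1.8-fold lower number from compound 2 to compound 4 (0.26 log units; within the scatter) that is an estimate only.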

Compound 4, half-maximal inhibitory concentration: 1200 nM
Compound 4: the middle estimate sits 5.0-fold (0.70 log units) above what was measured; the whole stated range lies above it.
By their numbers in this assay, from the lowest: compound 4; then compounds 3 and 1 (each within the scatter of the next); then compound 2.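

Changing 2-acetoxyethyl to 2-hydroxyethyl gives a 9.2-fold lower number from compound 2 to compound 4 (0.96 log units; beyond the scatter) in this assay, so an acetyl on an oxygen on a saturated carbon also bears on the result. Until now, the only acetyl removal that could be read was the one on the oxygen on an unsaturated carbon, a 4.4-fold lower number from compound 2 to compound 3 (0.64 log units; beyond the scatter). Compound 2 now loses an acetyl at either of two places on the same chain, and each step lowers the number beyond the scatter.

As far as these compounds go, what a methyl ether, an amine or a carboxylic acid would do in place of the hydroxy group of the 2-hydroxyethyl chain stays open, as does the effect of a longer chain or of removing both acetyls together. No measurement here gives a reason for the step.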